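The compounds below may be only part of what the source reports. "The series", "measured", "known", "first", "only" and "open" are said of these compounds alone.

Working notes on the series. All three measured compounds share one core and differ in the second acyl part of the imide. In an ADME assay on L6 cells (Rattus norvegicus) for cytotoxicity, read by resazurin assay, with a stated time of 72 h (a lower number here means a stronger inhibitor, a higher number a weaker inhibitor), compound 1 `N#Cc1ccc(C(=O)NC(=O)c2ccccc2O)cc1` gives 55 ug/mL. Compound 3 `O=C(NC(=O)C1CCCCC1)c1ccccc1O` gives 55 ug/mL in this assay, so compound 1 is level with compound 3 at the digits shown, and the two together hold the highest number of the three. Among the measured compounds shown here, compound 2 `O=C(NC(=O)c1ccccc1O)c1ccc2ccccc2c1` gives 21 ug/mL in this assay, a lower number than compound 1, and that gap lies beyond the usual scatter; compound 2 is therefore the compound furthest from compound 1 on the numbers so far.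

The next compound, compound 4 `COC(=O)CCC(=O)Nc1ccc(C(=O)NC(=O)c2ccccc2O)cc1`, has not yet been measured in this assay. It differs from compound 1 in one place: ((2-(methoxycarbonyl)ethyl)carbonyl)amino in place of cyano on an aromatic carbon. For the measured compounds named here, no pair of measured compounds carries a change of this kind, so there is no measured step to lean on. The working expectation is that the step from compound 1 to compound 4 in this assay stays within the scatter, a 1.1-fold higher number from compound 1 to compound 4 (0.04 log units; within the scatter), with no clear direction. Compound 4 is thus estimated at 60 ug/mL in this assay, within a range of 25 ug/mL to 130 ug/mL.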

Compound 4, half-maximal inhibitory concentration: > 50 ug/mL
Compound 4 gave a limit, no number; the forecaster's own chance of this, stated with the estimate: 15%; the middle value lies beyond the limit too.
By their numbers in this assay, from the lowest: compound 2; then compounds 1 and 3 (each within the scatter of the next).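

In this assay compound 4 gives > 50 ug/mL, which is a limit of the assay and not a number. The step from compound 1 to compound 4 therefore cannot be read: the limit of > 50 ug/mL in this assay, at which 1 of the 4 values shown sits.

The compounds shown leave open whether ((2-(methoxycarbonyl)ethyl)carbonyl)amino in place of cyano on the aromatic carbon changes the number in this assay at all, and in which direction.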